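The source may report more compounds than this note shows. Statements on the series, on what has been measured and on what is new or still open speak of the compounds shown alone.

Measured compounds in a functional assay on B16-F10 cells (Mus musculus) for antiproliferative activity, read by ELISA and MTT assay, with a stated time of 48 h; a lower number here means a stronger inhibitor, a higher number a weaker inhibitor:

compound 1 `O=C(/C=C/c1ccccc1)NS(=O)(=O)c1ccccc1`, compound 1 gives 3.5 ug/mL
compound 2 `Cc1ccc(S(=O)(=O)NC(=O)/C=C/c2ccccc2)cc1`, compound 2 gives 13.8 ug/mL
compound 3 `O=C(/C=C/c1ccc([N+](=O)[O-])cc1)NS(=O)(=O)c1ccccc1`, compound 3 gives 4.8 ug/mL

Three measured compounds share a cinnamoyl sulfonamide arrangement and differ only in a single substituent. From compound 1 to compound 3 the change is nitro in place of hydrogen on an aromatic carbon, and the resulting step, a 1.4-fold higher number from compound 1 to compound 3 (0.14 log units; within the scatter), is small, so the two numbers are not told apart here. From compound 1 to compound 2 the change is methyl in place of hydrogen on an aromatic carbon, and that step, a 3.9-fold higher number from compound 1 to compound 2 (0.60 log units; beyond the scatter), is the one clear movement in this set: the methyl-bearing compound 2 gives the highest number of the three.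

Compound 4 `Cc1ccc(S(=O)(=O)NC(=O)/C=C/c2ccc([N+](=O)[O-])cc2)cc1` has not yet been measured in this assay. Going by the values given here, it differs from compound 3 by methyl in place of hydrogen on an aromatic carbon, which is the same change as the one from compound 1 to compound 2, made on a core that carries the nitro group instead of hydrogen. Because the earlier step of a 3.9-fold higher number from compound 1 to compound 2 (0.60 log units; beyond the scatter) raised the number by a modest amount, and because the core difference a 1.4-fold higher number from compound 1 to compound 3 (0.14 log units; within the scatter) was small, compound 4 is expected to follow compound 2 in direction, with an expected step of roughly a 3.1-fold higher number from compound 3 to compound 4 (0.49 log units; beyond the scatter). Among the compounds with values here, on that basis compound 4 is estimated at about 15 ug/mL in this assay, most likely between 7 ug/mL and 35 ug/mL, with the single prior example of this change leaving wide room for scatter.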

Compound 4, half-maximal inhibitory concentration: 13.5 ug/mL
Compound 4: middle estimate off by 1.1-fold (0.05 log units), on the high side, within the range that was stated.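

In this assay, methyl in place of hydrogen on the nitro-bearing core gives a 2.8-fold higher number from compound 3 to compound 4 (0.45 log units; beyond the scatter), and this step matches the one seen on the core without the nitro group: the same change on two cores in this assay, a 3.9-fold higher number (0.60 log units; beyond the scatter) from compound 1 to compound 2 and a 2.8-fold higher number (0.45 log units; beyond the scatter) from compound 3 to compound 4, 1.4-fold (0.15 log units) apart, within the scatter of two such steps. Nitro in place of hydrogen on the methyl-bearing core gives a 1.0-fold lower number from compound 2 to compound 4 (0.01 log units; within the scatter), so this change stays unresolved on both cores: the same change on two cores in this assay, a 1.4-fold higher number (0.14 log units; within the scatter) from compound 1 to compound 3 and a 1.0-fold lower number (0.01 log units; within the scatter) from compound 2 to compound 4, 1.4-fold (0.15 log units) apart, within the scatter of two such steps. Within these four compounds, the methyl step carries over from one core to the other in direction and in a size that cannot be told apart, and the nitro change stays within the scatter on both, but two cores are a narrow test that shows neither that the pattern would hold on a further core nor why the methyl raises the number.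

The compounds shown leave open whether the step belongs to methyl in particular or would also appear with a longer chain such as ethyl, or with a methoxy group or a chlorine atom, at the same place on the ring. They also leave open whether an amine or a carboxylic acid in place of the nitro group would stay as close to the hydrogen compounds as nitro does here.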